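Lipophilicity of an oxime-ether series and a carbamate hydrazone

A few compounds are considered here, and "the series" means these few. Any claim that something is new, unique, unknown or untested is made for them only; others in the source may bear on it.

Measured compounds, with their values in a physicochemical assay for lipophilicity, using the shake flask method; a higher number here means a more lipophilic compound, a lower number a more polar compound:
compound 1, `C=CCO/N=C/c1c(N)ncnc1Oc1ccc(NC(=O)C2(C(=O)Nc3ccc(F)cc3)CC2)cc1F`, 3.65
compound 2, `Nc1ncnc(Oc2ccc(NC(=O)C3(C(=O)Nc4ccc(F)cc4)CC3)cc2F)c1/C=N/O`, 2.62
compound 3, `Nc1ncnc(Oc2ccc(NC(=O)C3(C(=O)Nc4ccc(F)cc4)CC3)cc2F)c1/C=N/OCCO`, 2.37

Compound 3 gives the lowest of the three numbers. Its nearest neighbour is compound 2, and a number 0.25 log units lower from compound 2 to compound 3 (within the scatter) stays within the scatter. Compound 1 stands furthest away; a number 1.28 log units lower from compound 1 to compound 3 (beyond the scatter) shows a gap well beyond the scatter, as does a number 1.03 log units lower from compound 1 to compound 2 (beyond the scatter).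

Compound 4, `CC(C)(C)OC(=O)N/N=C/c1c(N)ncnc1Oc1ccc(NC(=O)C2(C(=O)Nc3ccc(F)cc3)CC2)cc1F`, has not yet been measured. It differs from compound 3 in one place: (tert-butoxycarbonyl)amino in place of 2-hydroxyethoxy on a double-bonded nitrogen. The measured steps that bear on this change are those that alter the group at the same end of the shared core, namely a number 1.03 log units lower from compound 1 to compound 2 (beyond the scatter) and a number 1.28 log units lower from compound 1 to compound 3 (beyond the scatter). Both are large, and both run downward when the allyl is replaced by hydrogen or by a hydroxyethyl chain. Compound 4 carries a group with more heavy atoms than the one it replaces, so a step upward in this assay is expected, of a size comparable to those two steps: a number 1.23 log units higher from compound 3 to compound 4 (beyond the scatter). The estimate for compound 4 is therefore 3.6, with a range from 3 to 4.2.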

Compound 4, partition coefficient: 3.7
Compound 4: middle estimate off by 0.10 log units, on the low side, and the stated range covers the measured number.
By their numbers in this assay, from the lowest: compounds 3 and 2 (each within the scatter of the next); then compounds 1 and 4 (each within the scatter of the next).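

In this assay, the place on the double-bonded nitrogen now carries a group joined through nitrogen rather than oxygen, and (tert-butoxycarbonyl)amino gives a number 1.33 log units higher from compound 3 to compound 4 (beyond the scatter) and a number 1.08 log units higher from compound 2 to compound 4 (beyond the scatter). Large upward steps thus join the large downward ones already seen at this same place. Set against allyloxy, the same group gives a number 0.05 log units higher from compound 1 to compound 4 (within the scatter), so two groups of different make-up and size sit within the scatter of each other, and nothing given here accounts for these steps.

The compounds shown leave open how much of the rise belongs to the tert-butyl part and how much to the carbamate link. A plain amino group or a methoxycarbonylamino group at this place would separate the two contributions.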